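Trading a Trifluoromethylphenyl for a Chlorophenyl Group

The compounds below may be only part of what the source reports. "The series", "measured", "known", "first", "only" and "open" are said of these compounds alone.

Two compounds have been measured in a functional assay on L1210 cells (Mus musculus) for cytotoxicity, read by cell counting, with a stated time of 2 days; on this read-out lower numbers stand for stronger inhibition and higher numbers for weaker inhibition:
- compound 1 `Nc1ccc(/C=C2\SC(=O)N(Cc3ccc(C(F)(F)F)cc3)C2=O)cc1` gives 6000 nM
- compound 2 `C=C(Br)C(=O)Nc1ccc(/C=C2\SC(=O)N(Cc3ccc(C(F)(F)F)cc3)C2=O)cc1` gives 12000 nM

Compound 2 has the highest of these two numbers, and its nearest neighbour is compound 1. Among the compounds with values here, the only measured step is a 2.0-fold higher number from compound 1 to compound 2 (0.30 log units; within the scatter), a change at the nitrogen on the aromatic ring, and it stays within the scatter.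

Compound 3 `C=C(Br)C(=O)Nc1ccc(/C=C2\SC(=O)N(Cc3cccc(Cl)c3)C2=O)cc1` differs from compound 2 by 3-chlorophenyl in place of 4-(trifluoromethyl)phenyl on a saturated chain carbon bound to an amide-type nitrogen in a ring. Within the data shown here, no measured step touches this part of the shared core, so nothing in the data shows how this assay answers a change there. Without such evidence the expectation is no step beyond the scatter, so that compound 3 is estimated at 12000 nM, with a range from 3000 nM to 40000 nM. On these data alone, this estimate amounts to an expected step of no change at the digits printed from compound 2 to compound 3 (within the scatter), and the wide range reflects that the change is untested.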

Compound 3, half-maximal inhibitory concentration: 3400 nM
The estimate for compound 3 lay 3.5-fold (0.55 log units) above the measured number; the measured number falls inside the stated range.
By their numbers in this assay, from the lowest: compounds 3, 1 and 2 (each within the scatter of the next, the first and the last beyond it).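

In this assay, the group on the saturated chain carbon bound to an amide-type nitrogen in a ring turns out to matter: 3-chlorophenyl in place of 4-(trifluoromethyl)phenyl gives a 3.5-fold lower number from compound 2 to compound 3 (0.55 log units; beyond the scatter), the only single change shown so far that lies beyond the scatter. Within the data shown here, the earlier step, at the nitrogen on the aromatic ring, stayed within it, so this is the first sign that the assay responds to a change in the shared core. Nothing measured here bears on why the number fell.

This swap changes both the substituent and its place on the ring, so 4-chlorophenyl or 3-(trifluoromethyl)phenyl would be needed to tell those two apart, and plain phenyl to show what either substituent adds. On these data alone, whether the same swap would shift the number for compound 1 also remains open.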